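This account rests on a few compounds, and the source may have more. Where it says the series, first, only, none or still open, it means among the compounds named here.

Measured so far in a functional assay on HCT-116 cells (Homo sapiens) for inhibition, read by MTT assay, with a stated time of 72 h; on this read-out lower numbers stand for stronger inhibition of growth and higher numbers for weaker inhibition of growth:
compound 1 `CN1CCN(C(=O)/C=C/c2ccncc2-c2ccc3ccccc3c2)CC1`: > 30000 nM, a limit
compound 2 `NNC(=O)CCc1ccncc1-c1ccc2ccccc2c1`: > 30000 nM, a limit
compound 3 `O=C(CCc1ccncc1-c1ccc2ccccc2c1)N1CCOCC1`: > 30000 nM, a limit

Compound 1 is known only through a limit in this assay, and the other two values shown are limits as well. The measured set therefore reads as a single entry: the limit of > 30000 nM in this assay, at which 3 of the 3 values shown sit.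

The next compound is compound 4 `COC1CN(C(=O)/C=C/c2ccncc2-c2ccc3ccccc3c2)C1`, which keeps the core of compound 1 and changes only the group on the carbonyl carbon: 3-methoxyazetidin-1-yl in place of 4-methylpiperazin-1-yl on a carbonyl carbon.

Among the measured compounds shown here, the only measured step at a carbonyl carbon is a step that the two limits leave unreadable from compound 2 to compound 3. It gives no size to carry over to this change. For the measured compounds named here, three different groups on a carbonyl carbon have so far yielded no number, and no measured compound goes against that. The starting point for the expectation is compound 1 at > 30000 nM, which is a limit.

No change beyond the scatter is expected in this assay, and no direction can be supported. The expected step is a number no higher from compound 1 to compound 4 (the limit leaves the size open). A further limit is the most likely result. Should a number be reported, compound 4 is estimated at 30000 nM, with an expected range of 10000 nM to 60000 nM.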

Compound 4, concentration for 50% growth inhibition: > 30000 nM
Compound 4: only a limit was reported; the forecaster's own chance of this, stated with the estimate: 85%; the middle value sits exactly at the limit.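

In this assay compound 4 gives > 30000 nM, which is a limit. Compound 1 is likewise known only through a limit, so no step can be read from compound 1 to compound 4. The series still reads as a single entry: the limit of > 30000 nM in this assay, at which 4 of the 4 values shown sit. The compounds shown leave open which group on the carbonyl carbon, if any, would give a measurable growth-inhibition value.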